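From methyl to formyl on a brominated core

The source may hold more compounds than are shown below. What is called first, only, known or untested is meant among the compounds shown, and "the series" means these compounds.

Compound 1 `CS(=O)(=O)Cc1c(Br)c(O)c(O)c(Br)c1Br` gives 24000 nM
Compound 2 `Cc1c(Br)c(O)c(O)c(Br)c1Br` gives 14000 nM
Compound 3 `O=Cc1c(Br)c(O)c(O)c(Br)c1Br` has not yet been measured

For the measured compounds named here, in a functional assay (a lower number here means a stronger inhibitor, a higher number a weaker inhibitor), compound 2 gives 14000 nM and compound 1 gives 24000 nM as its only neighbour, and the two numbers lie within the scatter of each other. Compound 3 carries formyl in place of methyl on an aromatic carbon and keeps the rest of the core. Going by the values given here, one measured step bears on this, and only indirectly. It is a 1.7-fold lower number from compound 1 to compound 2 (0.23 log units; within the scatter) and it comes from hydrogen in place of methylsulfonyl on a saturated chain carbon bound to an aromatic carbon. Among the compounds with values here, no measured step tests formyl, so the data give no direction. The estimate amounts to a 1.1-fold lower number from compound 2 to compound 3 (0.03 log units; within the scatter) and no expected move beyond the scatter. In this assay the expected value for compound 3 is 13000 nM with an estimated range from 5000 nM to 35000 nM around it.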

Compound 3, half-maximal inhibitory concentration: 24700 nM
The estimate for compound 3 lay 1.9-fold (0.28 log units) below the measured number, and the stated range covers the measured number.
By their numbers in this assay, from the lowest: compounds 2, 1 and 3 (each within the scatter of the next).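

In this assay, for the compounds shown here, formyl in place of methyl on this aromatic carbon gives a 1.8-fold higher number from compound 2 to compound 3 (0.25 log units; within the scatter) and is the first direct test of formyl here, while formyl in place of (methylsulfonyl)methyl gives a 1.0-fold higher number from compound 1 to compound 3 (0.01 log units; within the scatter) on the same carbon. The position, ortho to two bromo groups and para to a hydroxy group, has now carried methyl, (methylsulfonyl)methyl and formyl with every step inside the scatter, so this read-out does not separate the three compounds. Nothing available bears on why the numbers stay so close.

As far as these compounds go, whether any group at this position can move the number beyond the scatter stays open, and a carboxylic acid, an amine or a longer chain there would test it. Equally open, from the compounds shown here alone, is what the hydroxy and bromo groups contribute, with all three compounds sharing them.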